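Trifluoromethyl Placed Next to the Ring Nitrogen

The source may report more compounds than this note shows. Statements on the series, on what has been measured and on what is new or still open speak of the compounds shown alone.

Measured so far in a functional assay on the whole organism (liver, strain Wistar) for inhibition, with Rattus norvegicus as the target, with a stated time of 3 h, at a dose of 3 mg/kg by the oral route; a higher number here means more inhibition at the dose given (going by the name of the read-out), a lower number less inhibition:
Compound 1 `O=[N+]([O-])c1cc(-c2nc(-c3c[n+]([O-])ccc3C(F)(F)F)no2)cc(O)c1O` gives 23.6%
Compound 2 `O=[N+]([O-])c1cc(-c2nc(-c3ccc[n+]([O-])c3)no2)cc(O)c1O` gives 77%
Compound 3 `O=[N+]([O-])c1cc(-c2nc(-c3ccc[n+]([O-])c3C(F)(F)F)no2)cc(O)c1O` gives 5.5%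

Compound 2 stands highest of the three, and both gaps to it are beyond the scatter. The two measured steps each turn on a single trifluoromethyl group on the six-membered ring: a number 53.4 percentage points higher from compound 1 to compound 2 (beyond the scatter) and a number 71.5 percentage points lower from compound 2 to compound 3 (beyond the scatter). In both cases the compound carrying trifluoromethyl shows far less inhibition, though the group sits at a different place each time.

Compound 4 `O=[N+]([O-])c1cc(-c2nc(-c3ccc(C(F)(F)F)[n+]([O-])c3)no2)cc(O)c1O` differs from compound 2 by trifluoromethyl in place of hydrogen on an aromatic carbon. Both measured steps bear on this change, since each is the same exchange, and both were large. A large fall is therefore expected: a number 57 percentage points lower from compound 2 to compound 4 (beyond the scatter). Compound 4 is estimated at 20%, with a likely range from 3% to 50%.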

Compound 4, a percentage reported as inhibition, in the whole organism at one dose (the size of the read-out at that dose, not a potency): 34.4%
Compound 4: the middle estimate sits 14.4 percentage points below what was measured, within the range that was stated.
By their numbers in this assay, from the lowest: compound 3; then compound 1; then compound 4; then compound 2.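

In this assay, trifluoromethyl on the aromatic carbon next to the ring nitrogen and para to a large group gives a number 42.6 percentage points lower from compound 2 to compound 4 (beyond the scatter), so this place also carries a large fall. Compound 2, with hydrogen, therefore stays above all three compounds carrying trifluoromethyl, at each place shown on the six-membered ring. No measurement at hand explains this fall.

Going by these compounds, whether a methyl group, a chlorine atom or an amine on this same carbon would also lower the inhibition stays open. So does how these compounds compare at other doses or times.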